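The compounds below may be only part of what the source reports. "The series", "measured", "known", "first", "only" and "open" are said of these compounds alone.

Measured in a functional assay on MCF7 cells (Homo sapiens) for cytotoxicity, read by MTT assay, with stated times of 6 h and 48 h; a lower number here means a stronger inhibitor, a higher number a weaker inhibitor:
- compound 1 `Cn1c(/C=C/C(=O)c2ccc[nH]2)cc(Br)c1Br`: 450 nM
- compound 2 `Cn1c(/C=C/C(=O)c2cccc(O)c2)cc(Br)c1Br`: 12800 nM
- compound 3 `Cn1c(-c2cc(-c3ccccc3)no2)cc(Br)c1Br`: >= 100000 nM (a limit)

Compound 3 has no exact number in this assay, only the limit >= 100000 nM. Compound 4 `Cn1c(-c2cc(-c3ccc[nH]3)no2)cc(Br)c1Br` keeps the rest of compound 3 and changes one group: 1H-pyrrol-2-yl in place of phenyl on an aromatic carbon, next to the ring nitrogen (1H-pyrrol-2-yl in place of phenyl on an aromatic carbon).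

Among the measured compounds shown here, no measured pair shows this exact swap, so the evidence is indirect. Compound 1, which carries a 1H-pyrrol-2-yl group, gives 450 nM. Compound 2, which carries a hydroxy-substituted phenyl instead, gives 12800 nM. Both differ from compound 3 in how that group is joined to the shared core, so this comparison is only a weak guide. A move toward stronger inhibition is therefore expected, though compound 4 may still reach the limit of the assay. The expected change is an at least 3.3-fold lower number from compound 3 to compound 4 (0.52 log units; beyond the scatter). For compound 4 the estimated value is 30000 nM, with an expected range of 5000 nM to 100000 nM.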

Compound 4, half-maximal inhibitory concentration: >= 100000 nM
Compound 4: only a limit was reported (the forecaster's own chance of this, stated with the estimate: 35%); middle value at least 3.3-fold (0.52 log units) from the limit.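

Compound 3 and compound 4 both carry only a limit, so no step between them can be read: the limit of >= 100000 nM in this assay, at which 2 of the 4 values shown sit.

The compounds shown leave open whether 1H-pyrrol-2-yl in place of phenyl changes the inhibition at all, and in which direction.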